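Adding a methoxy group to compound 1

The source may hold more compounds than are shown below. What is called first, only, known or untested is meant among the compounds shown, and "the series" means these compounds.

Compound 1 `COC(=O)C1=C(C)NC(=O)NC1c1ccc(O)cc1` gives 67 ug/mL
Compound 2 `COC(=O)C1=C(C)NC(=O)NC1c1ccc([N+](=O)[O-])cc1` gives 170 ug/mL
Compound 3 `COC(=O)C1=C(C)NC(=O)NC1c1ccccc1` gives 97.6 ug/mL

All three were read in a functional assay, read by spectrophotometry, in phosphate buffer, with a stated time of 10 min, at pH 6.6 (on this read-out higher numbers stand for an effect only at larger amounts of compound and lower numbers for an effect already at smaller amounts), and compound 1 stands clearly apart only from compound 2. The data show a 2.5-fold higher number from compound 1 to compound 2 (0.40 log units; beyond the scatter) but only a 1.5-fold higher number from compound 1 to compound 3 (0.16 log units; within the scatter) for the loss of the hydroxy group.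

Compound 4 `COC(=O)C1=C(C)NC(=O)NC1c1ccc(O)c(OC)c1` keeps the shared core and the hydroxy group of compound 1 and differs by methoxy in place of hydrogen on an aromatic carbon, ortho to a hydroxy group and meta to a large group.

Among the measured compounds shown here, no measured compound carries a methoxy group, so the measured steps bear on this change only indirectly. They are exchanges on the same aromatic ring, and besides those above there is a 1.7-fold lower number from compound 2 to compound 3 (0.24 log units; within the scatter) as well. The largest of them is modest, so no step beyond the scatter is expected in this assay in either direction. The expected step is a 1.1-fold lower number from compound 1 to compound 4 (0.05 log units; within the scatter) as an estimate. Compound 4 is estimated at 60 ug/mL with an expected range from 28 ug/mL to 125 ug/mL.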

Compound 4, half-maximal effective concentration: 57.1 ug/mL
Beside the measured number, compound 4's estimate is 1.1-fold (0.02 log units) above it; the measured number falls inside the stated range.
By their numbers in this assay, from the lowest: compounds 4, 1, 3 and 2 (each within the scatter of the next, the first and the last beyond it).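

In this assay, the methoxy group, ortho to a hydroxy group and meta to a large group, gives a 1.2-fold lower number from compound 1 to compound 4 (0.07 log units; within the scatter), so on this read-out compound 4 cannot be told apart from compound 1. The earlier steps shown here were all exchanges among hydroxy, nitro and hydrogen at a single place on the ring, whereas this one shows that a further place on that ring accepts a methoxy group while the hydroxy group stays, with no step beyond the scatter. No measurement shown offers an explanation for this result.

Going by these compounds, whether a longer chain such as an ethoxy group, or an amine, would read the same at this place remains open. So does whether methoxy here would read the same on the unsubstituted ring of compound 3, without the hydroxy group.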